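Urea-linked pyrazole series: chloro for trifluoromethyl on the terminal aryl

This account rests on a few compounds, and the source may have more. Where it says the series, first, only, none or still open, it means among the compounds named here.

Two members of this series have numbers in a functional assay on NCI-H322M cells (Homo sapiens) for inhibition, read by sulforhodamine B assay, with a stated time of 48 h, tested at 10 uM (a lower number here means a stronger effect, a higher number a weaker effect of the compound at the concentration tested), so far. Compound 1 `O=C(Nc1cccc(-n2cc(-c3ccncc3)c(-c3cc(O)cc(Cl)c3)n2)c1)Nc1ccc(Cl)c(Cl)c1` gives 19.5% in this assay. Compound 2 `COc1cc(Cl)cc(-c2nn(-c3cccc(NC(=O)Nc4ccc(Cl)c(C(F)(F)F)c4)c3)cc2-c2ccncc2)c1` gives 18.7% in this assay, and the two numbers sit within the scatter of each other, so nothing separates compound 1 from compound 2 on the data shown. Compound 3 `COc1cc(Cl)cc(-c2nn(-c3cccc(NC(=O)Nc4ccc(Cl)c(Cl)c4)c3)cc2-c2ccncc2)c1` is the next member to be measured in this assay. The change from compound 2 is chloro in place of trifluoromethyl on an aromatic carbon. Among the measured compounds shown here, no step between measured compounds is known for this change, so the size of its effect rests on analogy alone: compound 1 already carries the 3,4-dichlorophenyl urea end and gives 19.5%, and compound 2 with the 4-chloro-3-(trifluoromethyl)phenyl end gives 18.7%, a pair that stays within the scatter. The step from compound 2 to compound 3 is therefore expected to stay within the scatter, a number 1.3 percentage points higher from compound 2 to compound 3 (within the scatter), with no direction favoured. Compound 3 is expected to give 20% in this assay, with a range of 8% to 35%.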

Compound 3, a percentage reported as activity, at one concentration (the size of the read-out at that concentration, not a potency): 32.3%
Estimate against measurement, compound 3: 12.3 percentage points below; low and high end bracket the measured number.
By their numbers in this assay, from the lowest: compounds 2 and 1 (each within the scatter of the next); then compound 3.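

In this assay, the aromatic carbon that carries trifluoromethyl in compound 2 proves sensitive to this change: chloro in place of trifluoromethyl gives a number 13.6 percentage points higher from compound 2 to compound 3 (beyond the scatter), a weaker effect at the concentration tested. The 3,4-dichlorophenyl urea end does not by itself secure the effect seen for compound 1, since methyl in place of hydrogen on an oxygen on an aromatic ring gives a number 12.8 percentage points higher from compound 1 to compound 3 (beyond the scatter), so the closeness of compound 1 and compound 2 had hidden two separate single-place steps, each beyond the scatter and each leading to compound 3. No measurement at hand accounts for either step.

Still open, on these data alone, is whether chloro in place of trifluoromethyl has the same size of effect when the oxygen carries hydrogen rather than methyl, as one step seen with one partner group says nothing about the other. Also open, as far as these compounds go, is how a nitrile, a bromine or a methyl on the same aromatic carbon, or an ethyl or a longer chain on the oxygen, would read at this single concentration.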